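The source may hold more compounds than are shown below. What is called first, only, known or untested is meant among the compounds shown, and "the series" means these compounds.

Series notes, measured in a functional assay on HepG2 cells (Homo sapiens) for inhibition, read by MTT assay, with a stated time of 72 h, tested at 30 uM; a lower number here means less inhibition of growth, a higher number more inhibition of growth at the concentration tested:

- compound 1 `C=CCc1cc(O)c(O)c(CN2CCC(C)CC2)c1`: 57.6%
- compound 2 `C=CCc1ccc(OCc2cn(-c3ccc(C#N)cc3)nn2)c(O)c1`: 1.5%
- compound 3 `C=CCc1ccc(OCc2cn(-c3cc(OC)c(OC)c(OC)c3)nn2)c(O)c1`: 1.2%

Compound 2, at 1.5%, lies within the scatter of compound 3 and far beyond the scatter from compound 1, whose value is 57.6%. The two triazole-bearing compounds therefore read as level, and both sit near the bottom of the scale in this assay.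

Next in line is compound 4 `C=CCc1ccc(OCc2cn(-c3ccc(OC)cc3)nn2)c(O)c1`, which is not yet measured. It differs from compound 2 in one place: methoxy in place of cyano on an aromatic carbon. This puts methoxy in place of cyano on an aromatic carbon, para to a large group, so that 4-cyanophenyl becomes 4-methoxyphenyl.

Among the compounds with values here, the series holds no measured single-place step, so the expectation has only indirect support. Compound 3 also carries methoxy on the corresponding aromatic ring and gives 1.2%, which offers no sign of a rise. Compound 1 differs in too many places to guide this step.

The expected change is a number 1.5 percentage points higher from compound 2 to compound 4 (within the scatter), which is estimated to stay within the scatter, with no clear direction. For compound 4 the estimated value is 3%, with an expected range from 0% to 12%.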

Compound 4, percent growth inhibition at one concentration: 15.4%
Compound 4: the middle estimate sits 12.4 percentage points below what was measured, and the stated range ends below it.
By their numbers in this assay, from the lowest: compounds 3 and 2 (each within the scatter of the next); then compound 4; then compound 1.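

In this assay, within the data shown here, the exchange of cyano for methoxy gives a number 13.9 percentage points higher from compound 2 to compound 4 (beyond the scatter) and is the first single-place step. It shows that this aromatic carbon, para to a large group, is not silent in this read-out: going from 4-cyanophenyl to 4-methoxyphenyl moves the growth inhibition at the concentration tested, and compound 4 at 15.4% still shows only partial inhibition. No measurement bears on why this exchange moves the number, so the step stands as an observation only.

The compounds shown leave open whether the rise belongs to methoxy itself or would also appear with another group at this position, such as an amine, a carboxylic acid or a longer chain like ethoxy. Compound 4 differs from compound 3 in more than one place, so compound 3 at 1.2% cannot be set against this step, and the effect of further methoxy groups on the same ring remains unresolved.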